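Series notes on the acyl change from compound 1 to compound 4

A few compounds are considered here, and "the series" means these few. Any claim that something is new, unique, unknown or untested is made for them only; others in the source may bear on it.

Compound 1 `CCn1c(-c2cnc(C)nc2)nc2c(O[C@H]3CCN(C(=O)C4CC4)C3)ncnc21` gives 0.7 L/kg in an ADME assay (Rattus norvegicus, strain Wistar Han) for pharmacokinetics (on this read-out lower numbers stand for narrower distribution and higher numbers for wider distribution into tissues), the second highest of the three numbers recorded. Compound 2 `CCn1c(-c2cnc(C)nc2)nc2c(N[C@H]3CCN(C(=O)C4CCC4)C3)ncnc21` gives 0.5 L/kg, within the scatter of compound 1, whereas compound 3 `CCn1c(-c2cnc(C)nc2)nc2c(N[C@H]3CCN(C(=O)[C@H]4C[C@@H](OC)C4)C3)ncnc21` gives 1.5 L/kg, beyond it. Compound 4 `CCn1c(-c2cnc(C)nc2)nc2c(O[C@H]3CCN(C(=O)C4CCOC4)C3)ncnc21` differs from compound 1 by oxolan-3-yl in place of cyclopropyl on a carbonyl carbon. For the measured compounds named here, the only measured step that bears on this, as it too introduces an oxygen into the group on the carbonyl carbon, is a 3.0-fold higher number from compound 2 to compound 3 (0.48 log units; beyond the scatter). That pair adds a methoxy rather than a five-membered ring with one hetero atom, so the correspondence is loose. Expected for compound 4 is a 1.4-fold higher number from compound 1 to compound 4 (0.15 log units; within the scatter), a small widening that may not exceed the scatter. Compound 4 is thus estimated at 1 L/kg, between 0.5 L/kg and 2 L/kg.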

Compound 4, volume of distribution: 0.5 L/kg
For compound 4 the middle estimate is 2.0-fold (0.30 log units) above the measured one; the range from low to high includes it.
By their numbers in this assay, from the lowest: compounds 2, 4 and 1 (each within the scatter of the next); then compound 3.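

In this assay, the change to oxolan-3-yl gives a 1.4-fold lower number from compound 1 to compound 4 (0.15 log units; within the scatter) and so stays within the scatter, even though the incoming ring carries an oxygen and more heavy atoms than cyclopropyl. For the compounds shown here, an oxygen in the group on the carbonyl carbon therefore does not always go with a step beyond the scatter, and compound 4 goes against the only earlier oxygen step, a 3.0-fold higher number from compound 2 to compound 3 (0.48 log units; beyond the scatter) in this read-out. No measured data explain why these two steps differ.

Still open, on these data alone, is whether an amine or a carboxylic acid on this carbonyl carbon would shift the volume of distribution beyond the scatter. A longer chain in place of the ring is equally unresolved.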